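Working notes: aryl substitution in an amide series

The compounds below may be only part of what the source reports. "The series", "measured", "known", "first", "only" and "open" are said of these compounds alone.

Compound 1 `O=C(Nc1ccc2c(c1)B(O)OC2)c1ccccc1C(F)(F)F`: in a functional assay on PBMC cells (Homo sapiens) for inhibition, read by HTRF, with stated times of 15 min and 24 h (on this read-out higher numbers stand for weaker inhibition and lower numbers for stronger inhibition), compound 1 gives 4400 nM.
Compound 2 `O=C(Nc1ccc2c(c1)B(O)OC2)c1ccccc1`: compound 2 gives > 100000 nM, which is a limit of the assay and not a number.
Compound 3 `O=C(Nc1ccc2c(c1)B(O)OC2)c1ccccc1F`: compound 3 gives > 10000 nM, also a limit of the assay rather than a number.

All three share one core. Compound 1 and compound 2 differ by trifluoromethyl in place of hydrogen on an aromatic carbon, and this change makes an at least 22-fold higher number from compound 1 to compound 2 (1.35 log units; beyond the scatter). Compound 1 and compound 3 differ by fluoro in place of trifluoromethyl on an aromatic carbon, with an at least 2.2-fold higher number from compound 1 to compound 3 (0.35 log units; beyond the scatter). Compound 2 and compound 3 differ by fluoro in place of hydrogen on an aromatic carbon; here a step that the two limits leave unreadable from compound 2 to compound 3, as one value sits at the limit of > 100000 nM in this assay, at which 1 of the 3 values shown sits, and the other at the limit of > 10000 nM in this assay, at which 1 of the 3 values shown sits.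

Compound 4 `O=C(Nc1ccc2c(c1)B(O)OC2)c1cc(F)ccc1C(F)(F)F` is not yet measured. It differs from compound 1 by fluoro in place of hydrogen on an aromatic carbon. This is the same kind of change as that from compound 2 to compound 3, but the place is not the same: in compound 3 the fluoro sits ortho to a large group, in compound 4 it sits meta to a large group and para to a trifluoromethyl group. In this assay the step is expected to be a 1.3-fold lower number from compound 1 to compound 4 (0.10 log units; within the scatter), set beside the earlier step that the two limits leave unreadable from compound 2 to compound 3. For the measured compounds named here, that expectation rests only on compound 1 with its 4400 nM as the one number in hand, the earlier step being unreadable. Compound 4 is therefore estimated at 3500 nM, expected to fall between 1200 nM and 10000 nM.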

Compound 4, half-maximal inhibitory concentration: 8200 nM
Estimate against measurement, compound 4: 2.3-fold (0.37 log units) below; the range from low to high includes it.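

In this assay, fluoro in place of hydrogen on an aromatic carbon, meta to a large group and para to a trifluoromethyl group, gives a 1.9-fold higher number from compound 1 to compound 4 (0.27 log units; within the scatter), so on the core of compound 1 this change at this place does not move the read-out beyond the usual scatter. For the compounds shown here, the same kind of change from compound 2 to compound 3 cannot be read, as both values there are limits of the assay and not numbers, and the fluoro in compound 3 also stands at a different place from the one in compound 4. The series therefore shows one readable result for this change, on a core that carries trifluoromethyl, and does not show whether that result carries over to a core without trifluoromethyl or to another place on the ring.

The compounds shown leave open whether the result for fluoro holds on a core without trifluoromethyl when fluoro stands at the place it has in compound 4. They also leave open what happens in this assay when an amine, a carboxylic acid or a longer chain such as propyl stands at that place on the core of compound 1.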